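A methyl group gives way to (2-nitrophenyl)sulfonyl

A few compounds are considered here, and "the series" means these few. Any claim that something is new, unique, unknown or untested is made for them only; others in the source may bear on it.

Of the compounds shown here, three sharing one core have been tested in a functional assay on GOTO cells (Homo sapiens) for cytotoxicity, read by MTT assay, with a stated time of 3 days; on this read-out higher numbers stand for weaker inhibition and lower numbers for stronger inhibition. There, compound 1 `N#Cc1c(O)nc(SCc2nc3ccccc3[nH]2)nc1-c1ccccc1` gives 7.81 nM and compound 2 `N#Cc1c(Nc2ccccn2)nc(SCc2nc3ccccc3[nH]2)nc1-c1ccccc1` gives 2.5 nM. Compound 3 `CN1CCN(c2nc(SCc3nc4ccccc4[nH]3)nc(-c3ccccc3)c2C#N)CC1` gives 3.37 nM, which lies within the scatter of compound 2 and clearly lower than compound 1. Replacing the hydroxy group of the core produced only modest steps: a 3.1-fold lower number from compound 1 to compound 2 (0.49 log units; beyond the scatter) and a 2.3-fold lower number from compound 1 to compound 3 (0.37 log units; beyond the scatter). Exchanging one replacement for the other gave a 1.3-fold higher number from compound 2 to compound 3 (0.13 log units; within the scatter).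

Compound 4 `N#Cc1c(-c2ccccc2)nc(SCc2nc3ccccc3[nH]2)nc1N1CCN(S(=O)(=O)c2ccccc2[N+](=O)[O-])CC1` has (2-nitrophenyl)sulfonyl in place of methyl on an amine nitrogen in a ring. For the measured compounds named here, no measured step alters that nitrogen, so the evidence is indirect. The nearest guides are the small changes seen so far, above all a 1.3-fold higher number from compound 2 to compound 3 (0.13 log units; within the scatter), and they point to no clear direction. The expected result is therefore no shift beyond the scatter, although the size of the change calls for a wide range. The estimated step is a 1.2-fold higher number from compound 3 to compound 4 (0.07 log units; within the scatter). For compound 4 the estimate is 4 nM, with an expected range from 1.2 nM to 13 nM.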

Compound 4, half-maximal inhibitory concentration: 3 nM
Estimate against measurement, compound 4: 1.3-fold (0.12 log units) above; the measured number falls inside the stated range.
By their numbers in this assay, from the lowest: compounds 2, 4 and 3 (each within the scatter of the next); then compound 1.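

On the amine nitrogen in a ring, (2-nitrophenyl)sulfonyl in place of methyl leaves the number in this assay essentially where it was (a 1.1-fold lower number from compound 3 to compound 4 (0.05 log units; within the scatter)). For the compounds shown here, the earlier steps all changed a group on an aromatic carbon of the shared core, so this is the first look at the far end of the six-membered ring, and it shows that a single methyl and a much larger group carrying its own aromatic ring can sit on this nitrogen with no change beyond the scatter. Nothing shown here explains why the number holds steady despite so large a change.

As far as these compounds go, with only these two groups on this nitrogen, it remains open whether a plain phenylsulfonyl, an acetyl or a benzyl group would also stay in this range. From the compounds shown here alone, it is equally open whether the nitro group or the sulfonyl link contributes anything to the value of compound 4.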